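Methyl on the Saturated Ring Carbon of Compound 1

The source may hold more compounds than are shown below. What is called first, only, known or untested is meant among the compounds shown, and "the series" means these compounds.

Compound 1 `Cc1c(C(N)=O)cnc2c1CCN2` — 102 nM
Compound 2 `NC(=O)c1cnc2c(c1Cl)CCN2` — 92 nM

Of the compounds shown here, two sharing one core have been measured in an assay on isolated protein for inhibition of Nicotinamide N-methyltransferase (Homo sapiens), read by luminescence, with a stated time of 20 min; on this read-out lower numbers stand for stronger inhibition and higher numbers for weaker inhibition. Compound 1 gives 102 nM there, and compound 2, which carries chloro in place of methyl on an aromatic carbon, gives 92 nM. Within the data shown here, the single measured step, a 1.1-fold lower number from compound 1 to compound 2 (0.04 log units; within the scatter), lies within the scatter, so compound 1 and compound 2 cannot be told apart on this read-out.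

Compound 3 `Cc1c(C(N)=O)cnc2c1C[C@@H](C)N2` differs from compound 1 in another place altogether: methyl in place of hydrogen on a saturated ring carbon. Among the measured compounds shown here, no measured step touches the saturated part of the core, so the change from compound 1 to compound 2 offers no guide to its size or direction; it shows only that a small change elsewhere on this core left the number where it was. With nothing pointing either way, the step from compound 1 to compound 3 in this assay is expected to stay near the scatter, a 1.3-fold higher number from compound 1 to compound 3 (0.11 log units; within the scatter). Compound 3 is therefore estimated at 130 nM, with a range from 50 nM to 350 nM.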

Compound 3, half-maximal inhibitory concentration: 43 nM
For compound 3 the middle estimate is 3.0-fold (0.48 log units) above the measured one; measured number below the stated range.
By their numbers in this assay, from the lowest: compound 3; then compounds 2 and 1 (each within the scatter of the next).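

In this assay, the saturated ring carbon next to the ring nitrogen proves responsive to substitution: methyl in place of hydrogen there gives a 2.4-fold lower number from compound 1 to compound 3 (0.38 log units; beyond the scatter) and so moves the number beyond the scatter, a modest but readable change. Among these compounds, the only earlier step, a 1.1-fold lower number from compound 1 to compound 2 (0.04 log units; within the scatter) on swapping the aromatic substituent, said nothing about the saturated part of the core. The new step shows that this part accepts an added methyl and that the number falls rather than rises, though nothing at hand accounts for that fall.

On these data alone, whether the gain depends on the particular spatial arrangement of the methyl in compound 3, or would also appear with the opposite arrangement at that carbon, remains open. Also open, as far as these compounds go, are whether a longer chain such as ethyl, or a hydroxymethyl or an amine on the same carbon, would lower the number further or reverse the step, and whether the methyl would have the same effect on the chloro compound 2.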